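Nitro for fluoro on the chloro series

This account rests on a few compounds, and the source may have more. Where it says the series, first, only, none or still open, it means among the compounds named here.

Measured so far in a functional assay on A549 cells (Homo sapiens) for antiproliferative activity, read by MTT assay, with a stated time of 48 h; a lower number here means a stronger inhibitor, a higher number a weaker inhibitor
- compound 1 (`COc1ccc2nc(NC(c3cn(-c4ccccc4)nc3-c3ccc(F)cc3)c3c(O)ccc4ccccc34)sc2c1`) gives 33600 nM
- compound 2 (`COc1ccc2nc(NC(c3cn(-c4ccccc4)nc3-c3cccc([N+](=O)[O-])c3)c3c(O)ccc4ccccc34)sc2c1`) gives 52200 nM
- compound 3 (`Oc1ccc2ccccc2c1C(Nc1nc2ccc(Cl)cc2s1)c1cn(-c2ccccc2)nc1-c1ccc(F)cc1`) gives 32200 nM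

Compound 3 (32200 nM) sits within the scatter of both compound 1 and compound 2. The next compound, compound 4 (`O=[N+]([O-])c1ccc(-c2nn(-c3ccccc3)cc2C(Nc2nc3ccc(Cl)cc3s2)c2c(O)ccc3ccccc23)cc1`), has nitro in place of fluoro on an aromatic carbon, para to a large group, so 4-fluorophenyl becomes 4-nitrophenyl (nitro in place of fluoro on an aromatic carbon). The nearest measured change, 3-nitrophenyl in place of 4-fluorophenyl, gave a 1.6-fold higher number from compound 1 to compound 2 (0.19 log units; within the scatter) and is not the same isomer. Chloro in place of methoxy gave a 1.0-fold lower number from compound 1 to compound 3 (0.02 log units; within the scatter) and offers no reason to expect a different outcome in the chloro compounds. No step beyond the scatter is therefore expected in this assay with a slight lean towards a higher number. The expected change is a 1.4-fold higher number from compound 3 to compound 4 (0.15 log units; within the scatter) on this estimate. For compound 4 the estimated value is 45000 nM (expected range 24000 nM to 85000 nM).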

Compound 4, half-maximal inhibitory concentration: 57200 nM
Estimate against measurement, compound 4: 1.3-fold (0.10 log units) below; the range from low to high includes it.
By their numbers in this assay, from the lowest: compounds 3, 1, 2 and 4 (each within the scatter of the next).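

In this assay, 4-nitrophenyl in place of 4-fluorophenyl on the chloro compounds gives a 1.8-fold higher number from compound 3 to compound 4 (0.25 log units; within the scatter), so this para nitro group leaves the number within the scatter. The earlier compounds shown here covered only the 3-nitrophenyl change on the methoxy compounds, a 1.6-fold higher number from compound 1 to compound 2 (0.19 log units; within the scatter), and that step is also within the scatter, so neither nitro isomer has yet produced a step beyond it. No measured evidence on the cause of either result is available.

From the compounds shown here alone, whether an amine or a carboxylic acid in place of fluoro at this same position would produce a step beyond the scatter remains open. Also open is how 3-nitrophenyl behaves on the chloro compounds, since that single-place comparison with compound 3 is not among the compounds shown.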